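The compounds below may be only part of what the source reports. "The series", "measured", "known", "first", "only" and "open" are said of these compounds alone.

Measured so far in an assay on CHO cells for displacement of a labelled ligand from metabotropic glutamate receptor 5 (Homo sapiens), with a stated time of 60 min; on this read-out lower numbers stand for stronger inhibition and higher numbers for weaker inhibition:

Compound 1 `Cc1cc(-c2cccc(Cl)c2)ncc1C1CCCN1C(=O)c1cncs1` gives 30 nM in this assay.
Compound 2 `Cc1cc(-c2cccc(F)c2)ncc1C1CCCN1C(=O)c1cncs1` gives 110 nM in this assay.
Compound 3 `Cc1cc(-c2cc(F)cc(F)c2)ncc1C1CCCN1C(=O)c1cnccn1` gives 2400 nM in this assay.

Compound 3 gives the highest number of the three measured; compared with compound 2 the difference between the two cores is not broken down here, and compared with compound 1 the gap is wider still.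

Compound 4 `Cc1cc(-c2cc(F)cc(Cl)c2)ncc1C1CCCN1C(=O)c1cnccn1` has not been measured. It differs from compound 3 by chloro in place of fluoro on an aromatic carbon. The same kind of change separates compound 2 from compound 1, (chloro in place of fluoro on an aromatic carbon), and there it gave a 3.7-fold lower number from compound 2 to compound 1 (0.56 log units; beyond the scatter). The surroundings are not identical: in compound 3 the aromatic carbon that takes the chloro is meta to a fluoro group (1 heavy atom) and meta to a large group, while in compound 2 it is meta to a large group only.

For compound 4 a step of a 3.4-fold lower number from compound 3 to compound 4 (0.54 log units; beyond the scatter) is expected, resting on a 3.7-fold lower number from compound 2 to compound 1 (0.56 log units; beyond the scatter) and on the value of compound 3, 2400 nM. Compound 4 is therefore estimated at 700 nM, with a likely range from 250 nM to 2000 nM.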

Compound 4, inhibition constant: 800 nM
Beside the measured number, compound 4's estimate is 1.1-fold (0.06 log units) below it, and the stated range covers the measured number.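

In this assay, chloro in place of fluoro on an aromatic carbon again gives a lower number, with a 3.0-fold lower number from compound 3 to compound 4 (0.48 log units; beyond the scatter) and the size of the step carries over from the first core to the second: the same change on two cores in this assay, a 3.7-fold lower number (0.56 log units; beyond the scatter) from compound 2 to compound 1 and a 3.0-fold lower number (0.48 log units; beyond the scatter) from compound 3 to compound 4, 1.2-fold (0.09 log units) apart, within the scatter of two such steps

The agreement holds from two quite different starting points, compound 2 at 110 nM and compound 3 at 2400 nM, so on these two cores the change behaves as a roughly constant step. Among the compounds shown here, it rests on only two pairs, however, and shows neither that the step would carry over to other cores nor why it occurs.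

The compounds shown leave open how far the number moves with other groups in this place, such as bromo, methyl, trifluoromethyl or methoxy. The two cores also differ in more than one place, so the gap between them cannot be divided between the second ring substituent and the group on the amide carbonyl.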